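Thioether aryl swap on the diaminoquinoxaline core

The compounds below may be only part of what the source reports. "The series", "measured", "known", "first", "only" and "open" are said of these compounds alone.

Compound 3 `Nc1cc(N)c2nc(-c3ccccc3)c(Sc3ccc(Cl)c(Cl)c3)nc2c1` gives 4070 nM in a functional assay on MOLT-4 cells (Homo sapiens) for inhibition, read by sulforhodamine B assay, with a stated time of 48 h (on this read-out lower numbers stand for stronger inhibition of growth and higher numbers for weaker inhibition of growth), the higher of the two numbers recorded; compound 1 `CCOC(=O)[C@H](CCC(=O)O)NC(=O)c1ccc(CNc2nc3cc(N)cc(N)c3nc2-c2ccccc2)cc1` gives 1820 nM, a gap beyond the scatter. Compound 2 `Nc1cc(N)c2nc(-c3ccccc3)c(NCc3ccc(F)cc3)nc2c1` gives only a limit, < 100000 nM. Going by the values given here, the one measured step at the same position, a step that the limit leaves unreadable from compound 2 to compound 3, is unreadable because of the limit of < 100000 nM in this assay, at which 1 of the 3 values shown sits. Compound 4 `Nc1cc(N)c2nc(-c3ccccc3)c(Sc3ccc(F)cc3)nc2c1` differs from compound 3 by 4-fluorophenyl in place of 3,4-dichlorophenyl on a sulfur. Among the compounds with values here, no readable step bears on this exchange; the only guidance is that the compound carrying a 4-fluorine, compound 2, sits at the limit. Compound 4 is therefore expected to land near 8000 nM, with a range of 2000 nM to 40000 nM, the estimate meaning a step of a 2.0-fold higher number from compound 3 to compound 4 (0.29 log units; within the scatter) toward weaker inhibition.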

Compound 4, concentration for 50% growth inhibition: < 100000 nM
Compound 4 gave a limit, no number (the forecaster's own chance of this, stated with the estimate: 15%); the middle value is on the limit's open side.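

Neither the step from compound 3 to compound 4 nor the step from compound 2 to compound 4 can be read, because compound 4 gives only a limit: the limit of < 100000 nM in this assay, at which 2 of the 4 values shown sit.

Going by these compounds, whether 4-fluorophenyl in place of 3,4-dichlorophenyl on a sulfur weakens growth inhibition, and by how much, stays open.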